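The source may report more compounds than this note shows. Statements on the series, on what has been measured and on what is new or still open speak of the compounds shown alone.

Compound 1, `CN1C[C@H](C(=O)Nc2ccc(F)cc2)[C@@H](c2ccc(/C=C/C(=O)Nc3ccccc3N)cc2)C1`: 5 mL/min/kg
Compound 2, `CN1C[C@H](C(=O)Nc2ccc(C3CC3)cc2)[C@@H](c2ccc(/C=C/C(=O)Nc3ccccc3N)cc2)C1`: 12 mL/min/kg
Compound 3, `CN1C[C@H](C(=O)Nc2cccc(Cl)c2)[C@@H](c2ccc(/C=C/C(=O)Nc3ccccc3N)cc2)C1`: 7 mL/min/kg

All three share one core and differ only in the aryl group carried on the amide-type nitrogen. The read-out is an in vitro ADME assay on microsomes from liver (Homo sapiens) for pharmacokinetics, read by LC-MS, with a stated time of 10 min, tested at 1 uM; on this read-out lower numbers stand for slow clearance and higher numbers for fast clearance. Compound 3 sits close to both of its neighbours: the step of a 1.4-fold higher number from compound 1 to compound 3 (0.15 log units; within the scatter) and the step of a 1.7-fold lower number from compound 2 to compound 3 (0.23 log units; within the scatter) both stay inside the usual scatter, so no real separation between compound 3 and either of the others can be claimed. Among the measured compounds shown here, the only change in this set that went beyond the scatter was a 2.4-fold higher number from compound 1 to compound 2 (0.38 log units; beyond the scatter), a modest rise.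

Compound 4, `CN1C[C@H](C(=O)Nc2ccc(Cl)c(Cl)c2)[C@@H](c2ccc(/C=C/C(=O)Nc3ccccc3N)cc2)C1`, follows from compound 3 by a single change: chloro in place of hydrogen on an aromatic carbon. Nothing measured here tells directly what a second chloro group on this ring does. The closest guide is that swapping one small aryl substituent for another, as from compound 1 to compound 3, changed little, while the step from compound 1 to compound 2 shows a larger group can push the number up somewhat. A small rise at most is therefore expected, a 1.3-fold higher number from compound 3 to compound 4 (0.11 log units; within the scatter), and the estimate for compound 4 in this assay is 9 mL/min/kg, with a range from 5 mL/min/kg to 17 mL/min/kg.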

Compound 4, clearance: 14 mL/min/kg
Beside the measured number, compound 4's estimate is 1.6-fold (0.19 log units) below it; the measured number falls inside the stated range.
By their numbers in this assay, from the lowest: compounds 1, 3, 2 and 4 (each within the scatter of the next, the first and the last beyond it).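

In this assay, placing a chloro group on the ring carbon ortho to the existing chloro group and para to a large group gives a 2.0-fold higher number from compound 3 to compound 4 (0.30 log units; within the scatter), so this first look at a second chloro group on this ring shows a step that stays inside the usual scatter and cannot be called a real change on its own. The wider comparisons say more: a 2.8-fold higher number from compound 1 to compound 4 (0.45 log units; beyond the scatter) is a modest step beyond the scatter, making compound 4 the second compound after compound 2 to separate from compound 1, while a 1.2-fold higher number from compound 2 to compound 4 (0.07 log units; within the scatter) lies within the scatter, so the 3,4-dichlorophenyl and 4-cyclopropylphenyl groups cannot be told apart here. No supporting information is available to explain these numbers.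

The compounds shown leave open what a single chloro group para to the large group would give without the other chloro group, which would show whether the two chloro groups each contribute to the number. They also leave open whether an amine, a carboxylic acid or a methoxy group on this same ring carbon would keep the number near that of compound 3 or move it clearly away.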